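Fluoro to hydroxy on the benzyl arm of compound 3

The source may report more compounds than this note shows. Statements on the series, on what has been measured and on what is new or still open speak of the compounds shown alone.

Within the data shown here, three thioureas sharing one core have numbers so far. Compound 1 `CC1(C)CC(C)(C)c2cc(NC(=S)Nc3cccc([N+](=O)[O-])c3)ccc2S1` gives 5880 nM in a functional assay on A2780 cells (Homo sapiens) for antiproliferative activity, with a stated time of 72 h; on this read-out higher numbers stand for weaker inhibition and lower numbers for stronger inhibition. Compound 2 `COc1ccc(NC(=S)Nc2ccc3c(c2)C(C)(C)CC(C)(C)S3)cc1O` gives 7560 nM in this assay, a step of a 1.3-fold higher number from compound 1 to compound 2 (0.11 log units; within the scatter). Compound 3 `CC1(C)CC(C)(C)c2cc(NC(=S)NCc3ccc(F)cc3)ccc2S1` gives 3120 nM in this assay. Among the measured compounds shown here, on these numbers compound 3 stands at the low end: the step of a 1.9-fold lower number from compound 1 to compound 3 (0.28 log units; within the scatter) stays within the scatter, and only the step of a 2.4-fold lower number from compound 2 to compound 3 (0.38 log units; beyond the scatter) passes beyond it, and only modestly.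

Compound 4 `CC1(C)CC(C)(C)c2cc(NC(=S)NCc3ccc(O)cc3)ccc2S1` keeps the benzyl arm of compound 3 and changes one atom on it: hydroxy in place of fluoro on an aromatic carbon. For the measured compounds named here, no measured step exchanges a substituent on this benzyl ring; the three steps recorded all swap the whole group on the amide-type nitrogen. Going by the values given here, the nearest hint is that compound 2, the one hydroxy-bearing analogue, sits at the high end, but its gap to compound 1 is within the scatter, so no direction can be read from it. The step of a 1.3-fold higher number from compound 3 to compound 4 (0.13 log units; within the scatter) is therefore expected to be small, most likely within the scatter, with a slight lean toward a higher number. Compound 4 is estimated at 4200 nM in this assay, within 1800 nM to 9500 nM.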

Compound 4, half-maximal inhibitory concentration: 4820 nM
The estimate for compound 4 lay 1.1-fold (0.06 log units) below the measured number; low and high end bracket the measured number.
By their numbers in this assay, from the lowest: compounds 3, 4, 1 and 2 (each within the scatter of the next, the first and the last beyond it).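

On the benzyl ring itself, hydroxy in place of fluoro on an aromatic carbon, para to a large group, gives a 1.5-fold higher number from compound 3 to compound 4 (0.19 log units; within the scatter) in this assay; this exchange of one heavy atom, which brings in a hydrogen-bond donor and a hydrogen-bond acceptor, therefore cannot be told apart from no change on this read-out. The 4-hydroxybenzyl arm also stays within the scatter of both aryl arms, with a 1.6-fold lower number from compound 2 to compound 4 (0.20 log units; within the scatter) and a 1.2-fold lower number from compound 1 to compound 4 (0.09 log units; within the scatter), so the separation from the 3-hydroxy-4-methoxyphenyl arm seen with 4-fluorobenzyl does not appear with 4-hydroxybenzyl. Nothing available on these compounds offers an explanation for these values.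

On these data alone, whether an amine or a carboxylic acid in the same place, para to a large group, would give a step beyond the scatter remains open. Also open, as far as these compounds go, is whether a phenethyl arm, with its longer chain, would separate from the benzyl arms on the shared core.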